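The compounds below may be only part of what the source reports. "The series", "measured", "known", "first", "only" and "open" are said of these compounds alone.

This account concerns a small set of compounds tested in a functional assay on DU-145 cells (Homo sapiens) for inhibition, read by trypan blue exclusion, with a stated time of 96 h; a higher number here means a weaker inhibitor of growth, a lower number a stronger inhibitor of growth. Compound 1 `Cc1ccc(/C=C(\C(=O)c2ccc([N+](=O)[O-])cc2)S(=O)(=O)Cc2ccc(Cl)cc2)s1` gives 25000 nM in this assay. Compound 2 `COc1cc(/C=C(/Sc2ccc(Br)cc2)C(=O)c2ccc(Br)cc2)ccc1F` gives 10000 nM in this assay, and compound 3 `COc1cc(OC)c(/C=C(/SCc2ccc(F)cc2)C(=O)c2ccc(Cl)cc2)c(OC)c1` gives 10000 nM. Compound 2 stands level with compound 3 at the digits recorded, and the two together hold the lowest numbers of the three; compound 1 sits furthest from compound 2, with a number higher by a margin that lies beyond the scatter. For the measured compounds named here, no pair of measured compounds differs in only one place, so no single step can be read off among them.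

Compound 4 `O=C(/C(=C\c1ccc(Cl)cc1Cl)Sc1ccc(Br)cc1)c1ccc(Br)cc1` has not yet been tested. It differs from compound 2 as follows: 2,4-dichlorophenyl in place of 4-fluoro-3-methoxyphenyl on a double-bonded chain carbon bound to a double-bonded chain carbon. Going by the values given here, nothing among the measured compounds shows what such a change does in this assay. With the three measured numbers lying close together and no shown step to lean on, the step that the estimate means, no change at the digits printed from compound 2 to compound 4 (within the scatter), is expected to be none beyond the scatter. Compound 4 is therefore estimated to give 10000 nM, within a range from 4000 nM to 25000 nM.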

Compound 4, concentration for 50% growth inhibition: 1000 nM
Estimate against measurement, compound 4: 10-fold (1.00 log units) above; measured number outside the range, below it.
By their numbers in this assay, from the lowest: compound 4; then compounds 2 and 3 (each within the scatter of the next); then compound 1.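

In this assay, for the compounds shown here, 2,4-dichlorophenyl in place of 4-fluoro-3-methoxyphenyl on a double-bonded chain carbon bound to a double-bonded chain carbon gives a 10-fold lower number from compound 2 to compound 4 (1.00 log units; beyond the scatter), the first single change that can be read in this set, and it shows that the number responds to the group at this place. The exchange replaces a whole ring substituent pattern at once: the leaving group has 9 heavy atoms, including one oxygen and one fluorine, and 1 hydrogen-bond acceptor, while the entering group has 8 heavy atoms, including two chlorines, and no hydrogen-bond acceptors, so this one step cannot assign the shift to any single part of the exchange. No measurement bearing on the reason for the shift is available.

The compounds shown leave open whether the same exchange would give a similar step on the core of compound 1 or the core of compound 3. They also leave open how a ring carrying an amine or a carboxylic acid would behave at this place, and whether either chlorine alone would be enough to give such a step.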